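Swapping Cyanophenyl for Pyridyl: Cytotoxicity Expectation

The source may report more compounds than this note shows. Statements on the series, on what has been measured and on what is new or still open speak of the compounds shown alone.

Compound 1, `Cc1cccc(Cn2ccc3nc(-c4ccccc4)nc-3c2)c1`: in an ADME assay on MDBK cells (Bos taurus) for cytotoxicity (a higher number here means that more compound is tolerated, a lower number that less compound is tolerated), compound 1 gives > 100000 nM, which is a limit of the assay rather than a number.
Compound 2, `N#Cc1cccc(Cn2ccc3nc(-c4ccccc4)nc-3c2)c1`: in this assay compound 2 gives > 100000 nM, again a limit.

Compound 2 therefore has no exact value; both measurements shown end at the limit of > 100000 nM in this assay, at which 2 of the 2 values shown sit. Within the data shown here, the only measured step, a step that the two limits leave unreadable from compound 1 to compound 2, is a change of cyano in place of methyl on an aromatic carbon, and with both ends at the limit its size cannot be read.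

Compound 3, `c1ccc(-c2nc3ccn(Cc4cccnc4)cc-3n2)cc1`, has not been measured. It differs from compound 2 in one place: pyridin-3-yl in place of 3-cyanophenyl on a saturated chain carbon bound to an aromatic nitrogen. No readable step bears on this change, so no direction can be taken from the data. Compound 3 is expected to stay near the same limit, with an estimated step of a number no higher from compound 2 to compound 3 (the limit leaves the size open). The estimate for compound 3 is 100000 nM, ranging from 40000 nM to 250000 nM.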

Compound 3, half-maximal cytotoxic concentration: > 100000 nM
Compound 3: only a limit was reported; the forecaster's own chance of this, stated with the estimate: 80%; the middle value sits exactly at the limit.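

In this assay compound 3 gives > 100000 nM, which is a limit and not a number. No step can be read between compound 3 and compound 1 or compound 2, as all three end the same way: the limit of > 100000 nM in this assay, at which 3 of the 3 values shown sit.

The compounds shown leave open what concentration of any of them the cells fail to tolerate, and whether these changes affect it at all.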